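A few compounds are considered here, and "the series" means these few. Any claim that something is new, unique, unknown or untested is made for them only; others in the source may bear on it.

Of the compounds shown here, two have been measured in a functional assay for antagonist activity at Vanilloid receptor (Rattus norvegicus); on this read-out higher numbers stand for weaker inhibition and lower numbers for stronger inhibition. Compound 1 `COc1cc(C/N=C(\S)NCc2ccc(C(C)(C)C)cc2)ccc1OS(C)(=O)=O` gives 300 nM in this assay. Compound 2 `CCCS(=O)(=O)Nc1ccc(C/N=C(\S)NCc2ccc(C(C)(C)C)cc2)cc1` gives 4500 nM, the highest of the two numbers; the gap to compound 1 lies beyond the usual scatter. Compound 3 `CC(C)S(=O)(=O)Nc1ccc(C/N=C(\S)NCc2ccc(C(C)(C)C)cc2)cc1` has not yet been measured. It differs from compound 2 by isopropyl in place of propyl on a sulfonyl sulfur, the same atoms joined differently. Among the compounds with values here, no measured pair shows a step of this kind, so no change beyond the scatter is expected, in either direction. Compound 3 is therefore estimated at 4000 nM, with an expected range from 1500 nM to 12000 nM. The expected step is a 1.1-fold lower number from compound 2 to compound 3 (0.05 log units; within the scatter).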

Compound 3, half-maximal inhibitory concentration: 3800 nM
Estimate against measurement, compound 3: 1.1-fold (0.02 log units) above; the range from low to high includes it.
By their numbers in this assay, from the lowest: compound 1; then compounds 3 and 2 (each within the scatter of the next).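

In this assay, putting isopropyl in place of propyl on the sulfonyl sulfur gives a 1.2-fold lower number from compound 2 to compound 3 (0.07 log units; within the scatter), so the two values cannot be told apart. This is the only pair shown that differs in one place, and it shows that joining these same chain atoms differently leaves the read-out unmoved. Nothing measured here gives a reason for this. Still open, as far as these compounds go, is whether a shorter chain such as methyl, a longer chain such as butyl, or a phenyl ring on the sulfonyl sulfur would shift the number beyond the scatter.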